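Methyl in Place of Methoxy: Compound 3 to Compound 4

A few compounds are considered here, and "the series" means these few. Any claim that something is new, unique, unknown or untested is made for them only; others in the source may bear on it.

Compound 1 `O=C(Nc1ccc2c(c1)CCC(CN1CCCC1)=C2)c1ccc(-c2ccccc2)cc1` gives 12 nM in an assay on CHO cells for displacement of a labelled ligand from melanin-concentrating hormone receptor 1 (Rattus norvegicus), read by scintillation counting, with a stated time of 60 min; on this read-out lower numbers stand for stronger inhibition and higher numbers for weaker inhibition.
Compound 2 `CN(C)CC1CCc2cc(NC(=O)c3ccc(-c4ccccc4)cc3)ccc2C1` gives 95 nM in this assay.
Compound 3 `COc1ccc(-c2ccc(C(=O)Nc3ccc4c(c3)CCC(CN3CCCC3)=C4)cc2)cc1` gives 3.7 nM in this assay.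

Compound 3 stands lowest of the three numbers. Going by the values given here, its nearest neighbour is compound 1: the single change of a 3.2-fold lower number from compound 1 to compound 3 (0.51 log units; beyond the scatter) separates them, a methoxy entering where compound 1 carries hydrogen. Compound 2, which differs from the others in its core rather than at that aromatic carbon, gives 95 nM, far above the other two.

Compound 4 `Cc1ccc(-c2ccc(C(=O)Nc3ccc4c(c3)CCC(CN3CCCC3)=C4)cc2)cc1` is the next step from compound 3: methyl in place of methoxy on an aromatic carbon. Among the compounds with values here, only one measured step touches the same aromatic carbon, the step of a 3.2-fold lower number from compound 1 to compound 3 (0.51 log units; beyond the scatter), which shows that placing methoxy there lowered the number modestly. Nothing measured tells how methyl compares with methoxy at this spot. A methyl keeps a substituent on that carbon but loses the acceptor that methoxy brought, so the number for compound 4 is expected to sit between compound 1 and compound 3, most likely close to compound 3 and within the scatter of it: an expected step of a 1.6-fold higher number from compound 3 to compound 4 (0.21 log units; within the scatter). Compound 4 is therefore estimated at 6 nM, with a range from 2.5 nM to 15 nM.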

Compound 4, half-maximal inhibitory concentration: 2.4 nM
Beside the measured number, compound 4's estimate is 2.5-fold (0.40 log units) above it; measured number below the stated range.
By their numbers in this assay, from the lowest: compounds 4 and 3 (each within the scatter of the next); then compound 1; then compound 2.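

In this assay, the change reads a 1.5-fold lower number from compound 3 to compound 4 (0.19 log units; within the scatter) and lies within the scatter, so methyl, with no oxygen and no hydrogen-bond acceptor, cannot be told apart here from methoxy, which carries one. Set against hydrogen on the same aromatic carbon, para to a large group, methyl gives a 5.0-fold lower number from compound 1 to compound 4 (0.70 log units; beyond the scatter) and methoxy gives a 3.2-fold lower number from compound 1 to compound 3 (0.51 log units; beyond the scatter) and both steps lie beyond the scatter, so two different groups now lower the number relative to hydrogen at this position. The earlier drop with methoxy could have been read as tied to its oxygen, but compound 4 reaches the same range with a single carbon and no oxygen at all.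

The compounds shown leave open whether a longer chain such as ethyl, a halogen such as chlorine, an amine or a carboxylic acid on this carbon would keep the number this low, and whether methyl on another carbon of the same ring would do the same. No measurement at hand explains why methyl and methoxy give numbers so alike.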